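The source may report more compounds than this note shows. Statements on the series, on what has been measured and on what is new or still open speak of the compounds shown alone.

Measured so far:
compound 1, `COc1cc(-c2cc(C(=O)O)c3ccccc3n2)ccc1OCC(=O)Nc1ccccc1`, 0.7;
compound 2, `COc1cc(-c2cc(C(=O)O)c3ccccc3n2)ccc1OCC(=O)Nc1ccc(C)cc1`, 1.2;
compound 3, `COc1cc(-c2cc(C(=O)O)c3ccccc3n2)ccc1OCC(=O)Nc1ccc(F)cc1`, 1.1.

All three share one core and differ only in the group on the amide-type nitrogen. In a physicochemical assay for lipophilicity, using the shake flask method, in phosphate buffer, measured as octanol-water partition, at pH 7.4 (a higher number here means a more lipophilic compound, a lower number a more polar compound), compound 3 stands second highest of the three numbers: its nearest neighbour is compound 2, and the gap a number 0.10 log units lower from compound 2 to compound 3 (within the scatter) lies within the scatter, so the two cannot be told apart; the furthest is compound 1, and the step of a number 0.40 log units higher from compound 1 to compound 3 (beyond the scatter) is beyond the scatter.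

Compound 4, `COc1cc(-c2cc(C(=O)O)c3ccccc3n2)ccc1OCC(=O)Nc1cccc(C(F)(F)F)c1`, has not yet been measured. The change from compound 3 is 3-(trifluoromethyl)phenyl in place of 4-fluorophenyl on an amide-type nitrogen.

Among the compounds with values here, two measured steps bear on this. Putting a small group on the aromatic ring of compound 1 raised the number in both cases: a number 0.50 log units higher from compound 1 to compound 2 (beyond the scatter) and a number 0.40 log units higher from compound 1 to compound 3 (beyond the scatter). Within the data shown here, no measured step shows a trifluoromethyl group here, and none shows the 3-substituted pattern, so the size of the new step is less certain. Still, because a number 0.40 log units higher from compound 1 to compound 3 (beyond the scatter) already went up with a single fluorine, an upward step beyond the scatter is expected for compound 4, of about a number 0.60 log units higher from compound 3 to compound 4 (beyond the scatter). Compound 4 is therefore estimated at 1.7, with a range from 1.3 to 2.2.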

Compound 4, distribution coefficient: 1.3
For compound 4 the middle estimate is 0.40 log units above the measured one; the measured number falls inside the stated range.
By their numbers in this assay, from the lowest: compound 1; then compounds 3, 2 and 4 (each within the scatter of the next).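

Set against the bare phenyl ring of compound 1, the trifluoromethyl group still gives a clear step in this assay, a number 0.60 log units higher from compound 1 to compound 4 (beyond the scatter), so all three substituted rings now stand apart from the unsubstituted one. Among the substituted rings, however, replacing 4-fluorophenyl with 3-(trifluoromethyl)phenyl on the amide-type nitrogen gives a number 0.20 log units higher from compound 3 to compound 4 (within the scatter), and replacing 4-methylphenyl with the same group gives a number 0.10 log units higher from compound 2 to compound 4 (within the scatter), so these three compounds cannot be told apart here, even though 3-(trifluoromethyl)phenyl has 10 heavy atoms against 7 for 4-fluorophenyl. Nothing available gives a reason for this sameness.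

It remains open whether the same reading would hold for a ring carrying a group of another kind, such as an amine or a carboxylic acid, as the rings shown carry only methyl, fluoro or trifluoromethyl. The effect of the group also remains tangled with that of its place: trifluoromethyl appears only as 3-(trifluoromethyl)phenyl, while fluoro and methyl appear only as 4-fluorophenyl and 4-methylphenyl.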